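The source may hold more compounds than are shown below. What is called first, only, known or untested is meant among the compounds shown, and "the series" means these compounds.

Compound 1, `Nc1nn2c(O)cc(-c3ccccc3)nc2c1[N+](=O)[O-]`, in an ADME assay (Homo sapiens) for cytotoxicity (on this read-out lower numbers stand for higher toxicity in this test and higher numbers for lower toxicity in this test), gives > 100 ug/mL, which is a limit of the assay rather than a number.
Compound 2, `Nc1nn2c(O)cc(CNNc3ccc(F)cc3)nc2c1[N+](=O)[O-]`, gives > 100 ug/mL in this assay, again a limit rather than a number.
Compound 3, `COc1ccc(NNCc2cc(O)n3nc(N)c([N+](=O)[O-])c3n2)cc1`, gives 66.3 ug/mL in this assay.

Among the three values shown, compound 3 carries the only real number; the other two sit at the limit of > 100 ug/mL in this assay, at which 2 of the 3 values shown sit. Among the measured compounds shown here, the single measured step, an at least 1.5-fold lower number from compound 2 to compound 3 (0.17 log units; that floor lies within the scatter), swaps one group on an aromatic carbon for another, and its floor lies within the usual scatter, so it settles nothing on its own. Compound 4, `Nc1nn2c(O)cc(CNNCCO)nc2c1[N+](=O)[O-]`, has not yet been measured. It differs from compound 3 by 2-hydroxyethyl in place of 4-methoxyphenyl on an amine nitrogen. For the measured compounds named here, this change sits on an amine nitrogen, not on the aromatic carbon touched by the measured step, so that step bears on it only weakly, and no other measured pair speaks to it. A step in this assay is therefore not expected to exceed the scatter in either direction; the estimated change is a 1.2-fold higher number from compound 3 to compound 4 (0.08 log units; within the scatter). Compound 4 is expected to give about 80 ug/mL, within a range from 40 ug/mL to 160 ug/mL.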

Compound 4, half-maximal cytotoxic concentration: > 50 ug/mL
Compound 4 ended at the assay's limit; the forecaster's own chance of this, stated with the estimate: 40%; the middle value lies beyond the limit too.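

Compound 4 gives > 50 ug/mL in this assay, which is a limit and not a number. The steps to compound 4 from compound 1, compound 2 and compound 3 cannot be read. On these data alone, how 2-hydroxyethyl in place of 4-methoxyphenyl on an amine nitrogen shifts this read-out stays open.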